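Removing a Chloro Once More on a Second Core

The source may hold more compounds than are shown below. What is called first, only, known or untested is meant among the compounds shown, and "the series" means these compounds.

Compound 1 `Cc1cc(-c2nn(CC(O)CN3CCC(n4c(O)nc5ccccc54)CC3)c3c2CN(S(C)(=O)=O)CC3)ccc1Cl` and compound 2 `Cc1cc(-c2nn(CC(O)CN3CCC(n4c(O)nc5ccc(Cl)cc54)CC3)c3c2CN(S(C)(=O)=O)CC3)ccc1Cl` share one core, while compound 3 `CS(=O)(=O)N1CCc2c(c(-c3ccc(C(F)(F)F)cc3)nn2CCCN2CCC(n3c(O)nc4ccc(Cl)cc43)CC2)C1` and compound 4 `CS(=O)(=O)N1CCc2c(c(-c3ccc(C(F)(F)F)cc3)nn2CCCN2CCC(n3c(O)nc4ccccc43)CC2)C1` share another; how the two cores differ is not broken down here. In an assay on isolated protein for inhibition of cathepsin S (Homo sapiens) (a lower number here means a stronger inhibitor, a higher number a weaker inhibitor), compound 1 gives 60 nM, compound 2 gives 50 nM and compound 3 gives 30 nM. The difference between compound 2 and compound 1 is hydrogen in place of chloro on an aromatic carbon and the step it made was a 1.2-fold higher number from compound 2 to compound 1 (0.08 log units; within the scatter). The difference between compound 3 and compound 4 is hydrogen in place of chloro on an aromatic carbon; the place is described in the same words for both pairs, so this is the same change carried over to the second core. Compound 4 has not yet been measured in this assay. Because the same change gave a 1.2-fold higher number from compound 2 to compound 1 (0.08 log units; within the scatter), the step from compound 3 to compound 4 in this assay is expected to be a 1.2-fold higher number from compound 3 to compound 4 (0.08 log units; within the scatter), small and within the scatter. Compound 4 is therefore estimated to give about 36 nM in this assay, with an expected range from 20 nM to 70 nM.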

Compound 4, half-maximal inhibitory concentration: 50 nM
Compound 4: the middle estimate sits 1.4-fold (0.14 log units) below what was measured; measured number inside the range.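

In this assay, putting hydrogen in place of chloro on the second core gave a 1.7-fold higher number from compound 3 to compound 4 (0.22 log units; within the scatter), the change from 6-chloro-2-hydroxy-1H-benzimidazol-1-yl to 2-hydroxy-1H-benzimidazol-1-yl. Set beside the step on the first core, the two agree: the same change on two cores in this assay, a 1.2-fold higher number (0.08 log units; within the scatter) from compound 2 to compound 1 and a 1.7-fold higher number (0.22 log units; within the scatter) from compound 3 to compound 4, 1.4-fold (0.14 log units) apart, within the scatter of two such steps. This shows that, across these two pairs, the change carried from one core to the other without a step or a gap beyond the scatter; it does not show that chloro and hydrogen differ in this series at all, nor that the same would hold on any further core.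

The compounds shown carry only chloro or hydrogen at this aromatic carbon, so it remains open how a fluoro, a methoxy or a nitrile there would read in this assay. Also open, going by these compounds, is whether a carboxylic acid or an amine at the same place would give a step beyond the scatter on either core.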